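This account rests on a few compounds, and the source may have more. Where it says the series, first, only, none or still open, it means among the compounds named here.

Measured compounds in the series:
- compound 1, `CCCCCCc1nc(-c2ccc(CNC(=O)[C@H]3NCC[C@@H]3O)cc2)no1`: 49 nM
- compound 2, `CC1(c2nc(-c3ccc(CNC(=O)[C@H]4NCC[C@@H]4O)cc3)no2)CCCCC1`: 210 nM
- compound 3, `O=C(NCc1ccc(-c2noc(CCC3CC3)n2)cc1)[C@H]1NCC[C@@H]1O`: 5000 nM

In an assay on isolated protein for inhibition of sphingosine kinase 1 (Homo sapiens) (a lower number here means a stronger inhibitor, a higher number a weaker inhibitor), compound 3 gives the highest number of the three, with a 100-fold higher number from compound 1 to compound 3 (2.01 log units; beyond the scatter) and a 24-fold higher number from compound 2 to compound 3 (1.38 log units; beyond the scatter) both beyond the scatter, so compound 3 is the weakest inhibitor measured so far. Compound 1 gives 49 nM and compound 2 gives 210 nM in this assay; the step of a 4.3-fold higher number from compound 1 to compound 2 (0.63 log units; beyond the scatter) is modest.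

Compound 4, `O=C(NCc1ccc(-c2noc(C3CCCCCC3)n2)cc1)[C@H]1NCC[C@@H]1O`, has not yet been measured. Its difference from compound 3: cycloheptyl in place of 2-cyclopropylethyl on an aromatic carbon

The step that bears most directly on this change is a 24-fold higher number from compound 2 to compound 3 (1.38 log units; beyond the scatter), which ran in the opposite direction and was large; the step of a 100-fold higher number from compound 1 to compound 3 (2.01 log units; beyond the scatter) was larger still. Cycloheptyl, like 1-methylcyclohexyl, is a single carbon ring of seven heavy atoms attached directly to the aromatic carbon, so the return from compound 3 to compound 4 is expected to be a large step toward a lower number, roughly undoing a 24-fold higher number from compound 2 to compound 3 (1.38 log units; beyond the scatter), that is a 17-fold lower number from compound 3 to compound 4 (1.22 log units; beyond the scatter). Compound 4 is therefore expected to give about 300 nM in this assay, within a range of 100 nM to 1500 nM.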

Compound 4, half-maximal inhibitory concentration: 620 nM
Compound 4: the middle estimate sits 2.1-fold (0.32 log units) below what was measured, within the range that was stated.
By their numbers in this assay, from the lowest: compound 1; then compound 2; then compound 4; then compound 3.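

In this assay, cycloheptyl on this aromatic carbon recovers much of the loss seen with 2-cyclopropylethyl (an 8.1-fold lower number from compound 3 to compound 4 (0.91 log units; beyond the scatter)), so compound 3 does not set the level for carbocyclic groups at this position. The two ring groups bonded directly to the aromatic carbon are not interchangeable, as cycloheptyl falls short of 1-methylcyclohexyl (a 3.0-fold higher number from compound 2 to compound 4 (0.47 log units; beyond the scatter)), and a ring at this position is not needed for the lowest number in the series, as cycloheptyl also falls well short of the open-chain hexyl (a 13-fold higher number from compound 1 to compound 4 (1.10 log units; beyond the scatter)). No data bearing on the cause of these steps are available here.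

As far as these compounds go, whether cyclohexyl or cyclopentyl would sit nearer to compound 4 or to compound 2 remains open. Also open, from the compounds shown here alone, is whether a longer chain such as octyl would improve on hexyl, or a terminal amine on that chain would be tolerated.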